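Methoxy in place of fluoro: compound 3 to compound 4

The compounds below may be only part of what the source reports. "The series", "measured", "known", "first", "only" and "open" are said of these compounds alone.

Of the compounds shown here, three have been measured in a functional assay on Caco-2 cells (Homo sapiens) for cytotoxicity, with a stated time of 48 h; on this read-out higher numbers stand for weaker inhibition and lower numbers for stronger inhibition: compound 1 `O=[N+]([O-])c1ccc(CN2CCC(n3cc(CC(OCc4cc(-c5ccc(F)cc5)no4)c4ccc(Br)cc4)nn3)CC2)cc1`, compound 2 `COc1ccc(-c2cc(COC(Cc3cn(C4CCN(Cc5ccc([N+](=O)[O-])cc5)CC4)nn3)c3ccc(Br)cc3)on2)cc1` and compound 3 `O=[N+]([O-])c1ccc(CN2CCC(n3cc(CC(OCc4cc(-c5ccccc5F)no4)c4ccc(Br)cc4)nn3)CC2)cc1`. Compound 1 gives 3000 nM, compound 2 gives 3000 nM, and compound 3 gives 4000 nM. Compound 3 carries the highest of the three numbers, yet its steps to both others stay within the scatter: a 1.3-fold higher number from compound 1 to compound 3 (0.12 log units; within the scatter) and a 1.3-fold higher number from compound 2 to compound 3 (0.12 log units; within the scatter). The unmeasured compound 4 `COc1ccccc1-c1cc(COC(Cc2cn(C3CCN(Cc4ccc([N+](=O)[O-])cc4)CC3)nn2)c2ccc(Br)cc2)on1` differs from compound 3 in one place: methoxy in place of fluoro on an aromatic carbon.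

Among the compounds with values here, one measured step bears directly on this exchange, the same swap carried out on the 4-fluorophenyl group: no change at the digits printed from compound 1 to compound 2 (within the scatter). There, methoxy in place of fluoro left the number where it was. Whether the same holds when the swap is made on the 2-fluorophenyl group is not shown by any measured pair, so only that single step can be drawn on. From it, no step beyond the scatter is expected in this assay from compound 3 to compound 4, no change at the digits printed from compound 3 to compound 4 (within the scatter). Compound 4 is therefore estimated at 4000 nM, with a range from 2000 nM to 8000 nM.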

Compound 4, half-maximal inhibitory concentration: > 25000 nM
Compound 4 gave a limit, no number (the forecaster's own chance of this, stated with the estimate: 5%); middle value at least 6.2-fold (0.79 log units) from the limit.
By their numbers in this assay, from the lowest: compounds 1, 2 and 3 (each within the scatter of the next). At a limit, above all of these: compound 4.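

In this assay compound 4 stands at a limit and not at a number: > 25000 nM. Measured against that limit, the 2-methoxyphenyl group separates from the 2-fluorophenyl, 4-fluorophenyl and 4-methoxyphenyl groups, with an at least 6.2-fold higher number from compound 3 to compound 4 (0.79 log units; beyond the scatter), an at least 8.3-fold higher number from compound 2 to compound 4 (0.92 log units; beyond the scatter) and an at least 8.3-fold higher number from compound 1 to compound 4 (0.92 log units; beyond the scatter), whereas those three groups stay within the scatter of one another. Methoxy in place of fluoro is therefore not a neutral exchange across this series, and its outcome differs between the 4-fluorophenyl and 2-fluorophenyl compounds: the same change on two cores in this assay, no change at the digits printed (within the scatter) from compound 1 to compound 2 and an at least 6.2-fold higher number (0.79 log units; beyond the scatter) from compound 3 to compound 4, at least 6.2-fold (0.79 log units) apart, beyond the scatter of two such steps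

Within the data shown here, the full size of these steps cannot be read from a limit, and with only one exchange at this ring position it remains open whether the loss of effect belongs to methoxy alone. A hydroxyl, an amine or an ethoxy group on the same aromatic carbon would show whether the number stays with compounds 1, 2 and 3 or goes the way of compound 4.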